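From thiophen-3-yl to 1-benzofuran-2-yl

A few compounds are considered here, and "the series" means these few. Any claim that something is new, unique, unknown or untested is made for them only; others in the source may bear on it.

Among the measured compounds shown here, in a functional assay on HL-60 cells (Homo sapiens) for antiproliferative activity, read by XTT assay, with a stated time of 72 h (a higher number here means a weaker inhibitor, a lower number a stronger inhibitor), compound 2 `Cc1ncnc2c1c(-c1ccsc1)cn2[C@@H]1O[C@H](CO)[C@@H](O)[C@H]1O` gives 350 nM, the lower of the two numbers so far. Compound 1 `Cc1ncnc2c1c(-c1cccs1)cn2[C@@H]1O[C@H](CO)[C@@H](O)[C@H]1O` gives 5730 nM. Compound 3 `Cc1ncnc2c1c(-c1cc3ccccc3o1)cn2[C@@H]1O[C@H](CO)[C@@H](O)[C@H]1O` differs from compound 2 by one change: 1-benzofuran-2-yl in place of thiophen-3-yl on an aromatic carbon. For the measured compounds named here, only one measured step bears on it: thiophen-3-yl in place of thiophen-2-yl, a large change of a 16-fold lower number from compound 1 to compound 2 (1.21 log units; beyond the scatter). On these data alone, the entering group is also a 2-yl group, as in compound 1, so a large step to a higher number is expected in this assay, though the fused ring is untested. The expected change is an 8.6-fold higher number from compound 2 to compound 3 (0.93 log units; beyond the scatter). For compound 3 the estimate is 3000 nM, with a range of 600 nM to 15000 nM.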

Compound 3, half-maximal inhibitory concentration: > 20000 nM
Compound 3: a limit, no number; the forecaster's own chance of this, stated with the estimate: 20%; at least 6.6-fold (0.82 log units) between middle value and limit.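

For compound 3 the result in this assay is a limit and not a number: the limit of > 20000 nM in this assay, at which 1 of the 3 values shown sits. The change to 1-benzofuran-2-yl gives an at least 57-fold higher number from compound 2 to compound 3 (1.75 log units; beyond the scatter), and even against thiophen-2-yl, the poorer of the two thiophene groups, it gives an at least 3.4-fold higher number from compound 1 to compound 3 (0.54 log units; beyond the scatter). Among the compounds shown here, this position therefore responds not only to how a thiophene is attached, as the earlier compounds showed, but also to replacing it with a fused aromatic group.

The compounds shown leave open whether the six-membered aromatic ring or the oxygen in place of sulfur accounts for this loss. On these data alone, how a plain furan-2-yl or phenyl group would read here also remains open.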